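The compounds below may be only part of what the source reports. "The series", "measured", "known", "first", "only" and "open" are said of these compounds alone.

In a functional assay on HL-60 cells (Homo sapiens) for cytotoxicity, read by CCK-8 assay, with a stated time of 24 h (on this read-out higher numbers stand for weaker inhibition and lower numbers for stronger inhibition), two compounds have been measured so far. Compound 1 `C=CC(=O)N1C(=O)CC(c2cccs2)Sc2ccccc21` gives 695000 nM, while compound 2 `C=CC(=O)N1C(=O)CC(c2ccc(-c3ccccc3)cc2)Sc2ccccc21` gives 118000 nM, the lower of the two numbers, and the gap between them lies beyond the usual scatter. Compound 3 `C=CC(=O)N1C(=O)CC(c2ccc(C#N)cc2)Sc2ccccc21` differs from compound 2 in one place: cyano in place of phenyl on an aromatic carbon, with cyano in place of phenyl on an aromatic carbon, para to a large group. For the measured compounds named here, no measured step shows the effect of this change in this assay, so the only guide is the range of the two values, from compound 2 at 118000 nM to compound 1 at 695000 nM. A moderate rise within that range is expected, meaning weaker inhibition, and the estimated move is a 2.5-fold higher number from compound 2 to compound 3 (0.41 log units; beyond the scatter). For compound 3 the estimated value is 300000 nM, with an expected range from 100000 nM to 800000 nM.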

Compound 3, half-maximal inhibitory concentration: 115000 nM
Compound 3: the middle estimate sits 2.6-fold (0.42 log units) above what was measured, within the range that was stated.
By their numbers in this assay, from the lowest: compounds 3 and 2 (each within the scatter of the next); then compound 1.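

In this assay cyano in place of phenyl on an aromatic carbon, para to a large group, gives a 1.0-fold lower number from compound 2 to compound 3 (0.01 log units; within the scatter) and so shows that the phenyl ring is not needed at this position to keep the number where compound 2 has it. With 4-cyanophenyl in place of thiophen-2-yl on a saturated ring carbon, the reading is a 6.0-fold lower number from compound 1 to compound 3 (0.78 log units; beyond the scatter) and this lies beyond the scatter, so compound 1 now stands apart from two compounds rather than one. Nothing at hand gives a reason for either step.

The compounds shown leave open whether an amine, a carboxylic acid or a methoxy group on this same aromatic carbon would also stay within the scatter of compound 2. They also leave open whether any group there would move the number beyond the scatter in either direction.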